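This account rests on a few compounds, and the source may have more. Where it says the series, first, only, none or still open, it means among the compounds named here.

Measured to date:
compound 1, `Cc1ccc(S(=O)(=O)/N=C(/CCNC2=CC(=O)c3ccccc3C2=O)Nc2ccc(Cl)cc2)cc1` — in a functional assay on HeLa cells (Homo sapiens) for cytotoxicity, read by MTT assay, with a stated time of 48 h (on this read-out higher numbers stand for weaker inhibition and lower numbers for stronger inhibition), compound 1 gives 13400 nM
compound 2, `Cc1ccc(S(=O)(=O)/N=C(/CCNC2=CC(=O)c3ccccc3C2=O)Nc2ccc(F)cc2)cc1` — compound 2 gives 5890 nM
compound 3, `Cc1ccc(S(=O)(=O)/N=C(/CCNC2=CC(=O)c3ccccc3C2=O)Nc2cc(F)c(F)c(F)c2)cc1` — compound 3 gives 8580 nM

Compound 2 holds the lowest of the three numbers. Its nearest neighbour is compound 3, with a 1.5-fold higher number from compound 2 to compound 3 (0.16 log units; within the scatter), a gap that sits within the scatter, so no order between compound 2 and compound 3 can be read. For the measured compounds named here, its furthest neighbour is compound 1, with a 2.3-fold lower number from compound 1 to compound 2 (0.36 log units; beyond the scatter), the only step among the three that clears the scatter. The third step, a 1.6-fold lower number from compound 1 to compound 3 (0.19 log units; within the scatter), also stays within the scatter.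

Compound 4, `Cc1ccc(S(=O)(=O)/N=C(/CCNC2=CC(=O)c3ccccc3C2=O)NC(C)C)cc1`, is the next step from compound 2. The change is isopropyl in place of 4-fluorophenyl on an amine nitrogen. Going by the values given here, every measured step in this set swaps one halogenated phenyl for another halogenated phenyl on the same amine nitrogen; no measured step replaces the phenyl ring by an alkyl group. The measured steps therefore bear on this change only loosely, and all of them were modest at most. No direction is supported by the numbers in hand, so the expected step in this assay is none beyond the scatter, with wide uncertainty on either side.

Compound 4 is accordingly expected to give about 9000 nM in this assay, in a range from 3000 nM to 30000 nM. The expected change from compound 2 is a 1.5-fold higher number from compound 2 to compound 4 (0.18 log units; within the scatter).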

Compound 4, half-maximal inhibitory concentration: 30200 nM
Compound 4: middle estimate off by 3.4-fold (0.53 log units), on the low side; measured number above the stated range.
By their numbers in this assay, from the lowest: compounds 2, 3 and 1 (each within the scatter of the next, the first and the last beyond it); then compound 4.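

In this assay, replacing a halogenated phenyl with isopropyl on this amine nitrogen gives the largest steps seen at this position: a 5.1-fold higher number from compound 2 to compound 4 (0.71 log units; beyond the scatter) and a 3.5-fold higher number from compound 3 to compound 4 (0.55 log units; beyond the scatter) and a 2.3-fold higher number from compound 1 to compound 4 (0.35 log units; beyond the scatter) all lie beyond the scatter and all point towards weaker inhibition. Changing the halogen pattern on the phenyl ring moves the number beyond the scatter only between compound 1 and compound 2, whereas leaving the aromatic ring for this branched alkyl group does so against all three aryl compounds, and none of the four compounds goes against this pattern. Nothing measured here accounts for the shift.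

The compounds shown leave open whether the difference follows the aromatic ring itself or simply the larger group, and cyclohexyl on the same nitrogen would help separate those two readings. They also leave open how a phenyl ring without halogen, a benzyl group or a longer chain such as n-butyl would fall relative to compound 2 and compound 4.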